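This account rests on a few compounds, and the source may have more. Where it says the series, first, only, none or still open, it means among the compounds named here.

In a functional assay on NT2 cells (Homo sapiens) for inhibition (a lower number here means a stronger inhibitor, a higher number a weaker inhibitor), compound 1 `CCC(C(=O)N[C@@H](CC(=O)O)C(C)=O)n1cc(C(C)(C)C)nc(NCc2nonc2C)c1=O` gives 5.12 nM and compound 2 `CCC(C(=O)N[C@@H](CC(=O)O)C(=O)CSCc1ccccc1)n1ccnc(NCc2cccs2)c1=O` gives 4.56 nM so the two lie within the usual scatter of each other. Compound 3 `CCC(C(=O)N[C@@H](CC(=O)O)C(=O)CSCc1ccccc1)n1ccnc(NCc2cncs2)c1=O` differs from compound 2 in one place 1,3-thiazol-5-yl in place of thiophen-2-yl on a saturated chain carbon bound to a nitrogen on an aromatic ring with 1,3-thiazol-5-yl in place of thiophen-2-yl on a saturated chain carbon bound to a nitrogen on an aromatic ring. Within the data shown here, no measured pair of compounds shows this swap, so the estimated step of a 1.2-fold higher number from compound 2 to compound 3 (0.08 log units; within the scatter) is expected to stay within the usual scatter, with no firm direction. Compound 3 is estimated to read 5.5 nM within an expected range of 1.8 nM to 17 nM in this assay when it is tested.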

Compound 3, half-maximal inhibitory concentration: 3.42 nM
Compound 3: the middle estimate sits 1.6-fold (0.21 log units) above what was measured, and the stated range covers the measured number.
By their numbers in this assay, from the lowest: compounds 3, 2 and 1 (each within the scatter of the next).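

In this assay, 1,3-thiazol-5-yl in place of thiophen-2-yl on a saturated chain carbon bound to a nitrogen on an aromatic ring gives a small step (a 1.3-fold lower number from compound 2 to compound 3 (0.12 log units; within the scatter)). This place therefore accepts a five-membered aromatic ring with 2 hetero atoms as well as one with 1 hetero atom, with no readable change in the number. Nothing available explains this result. The compounds shown leave open whether a phenyl ring, a pyridin-3-yl ring or an open propyl chain would read alike at this place.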